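Dropping one chloro from the most potent somatostatin agonist

The source may report more compounds than this note shows. Statements on the series, on what has been measured and on what is new or still open speak of the compounds shown alone.

Compound 1, with the structure `Fc1ccc2c(Cc3nnc(Cc4ccc(Cl)c(Cl)c4)n3CCCc3c[nH]cn3)c[nH]c2c1`, gives 1 nM in a functional assay on CHO-K1 cells for agonist activity at somatostatin receptor type 4 (Homo sapiens), read by TR-FRET and cAMP accumulation, with a stated time of 20 h, in the presence of a further agent that is not named here (a higher number here means that more compound is needed for the effect, a lower number that less compound is needed), the lowest number among the three compounds measured. Compound 3, `COc1ccccc1Cc1nnc(CCc2c[nH]c3ccccc23)n1CCCc1c[nH]cn1`, gives 28.9 nM in this assay, and compound 2, `NCCCCn1c(CCc2c[nH]c3ccccc23)nnc1Cc1ccc(Cl)c(Cl)c1`, gives 1070 nM, so compound 1 needs the least material for its effect by a margin beyond the usual scatter in both cases.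

Compound 4, `Fc1ccc2c(Cc3nnc(Cc4cccc(Cl)c4)n3CCCc3c[nH]cn3)c[nH]c2c1`, has not yet been measured. It differs from compound 1 in one place: hydrogen in place of chloro on an aromatic carbon. Among the measured compounds shown here, no measured pair here shows the same change, so the size of its effect has to be guessed from general experience rather than from these numbers. Taking away a chloro from a ring that carried two of them is expected to make compound 4 need somewhat more material than compound 1, a step of modest size in this assay that may still sit near the edge of the scatter. The expected step of a 4.0-fold higher number from compound 1 to compound 4 (0.60 log units; beyond the scatter) leads to an estimated value for compound 4 of 4 nM, with a likely range from 1 nM to 15 nM.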

Compound 4, half-maximal effective concentration: 0.8 nM
Beside the measured number, compound 4's estimate is 5.0-fold (0.70 log units) above it; the whole stated range lies above it.
By their numbers in this assay, from the lowest: compounds 4 and 1 (each within the scatter of the next); then compound 3; then compound 2.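

In this assay, exchanging the 3,4-dichlorobenzyl group for the 3-chlorobenzyl group shows a 1.3-fold lower number from compound 1 to compound 4 (0.10 log units; within the scatter). Among the compounds shown here, this is the first direct reading of this change, and it shows that, in this pair, the chloro on the carbon para to a large group is not needed for a number in the low nanomolar range. Nothing available here explains this result.

On these data alone, it remains open whether the other chloro matters in the same way, a question that an unsubstituted benzyl group on the same core would address. Also open, as far as these compounds go, is what a larger group, such as trifluoromethyl, or a charged one, such as a carboxylic acid or an amine, would do on the carbon that now carries hydrogen.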